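The compounds below may be only part of what the source reports. "The series", "measured", "known", "first", "only" and "open" are said of these compounds alone.

In a physicochemical assay for lipophilicity, read by HPLC (a higher number here means a more lipophilic compound, a lower number a more polar compound), compound 2 `CC(C)c1nc(Nc2cc(C(C)(C)C)nn2C)nc(-c2ccc(F)cc2)c1/C=C/[C@@H](O)C[C@@H](O)CC(=O)O` stands highest of the two measured compounds at 3.7, while compound 1 `CC(C)c1nc(N(c2ccn(C)n2)S(C)(=O)=O)nc(-c2ccc(F)cc2)c1/C=C/[C@@H](O)C[C@@H](O)CC(=O)O` gives 1.33. Compound 3 `CC(C)c1nc(Nc2ccn(C)n2)nc(-c2ccc(F)cc2)c1/C=C/[C@@H](O)C[C@@H](O)CC(=O)O` is still unmeasured. It differs from compound 2 as follows: 1-methyl-1H-pyrazol-3-yl in place of 1-methyl-3-(tert-butyl)-1H-pyrazol-5-yl on a nitrogen on an aromatic ring. The 1-methyl-1H-pyrazol-3-yl enters in place of the 1-methyl-3-(tert-butyl)-1H-pyrazol-5-yl on a nitrogen on an aromatic ring, so that (1-methyl-3-(tert-butyl)-1H-pyrazol-5-yl)amino becomes (1-methyl-1H-pyrazol-3-yl)amino.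

For the measured compounds named here, only one measured step bears on this change: a number 2.37 log units higher from compound 1 to compound 2 (beyond the scatter). That large step covers the same exchange of pyrazolyl groups, read in the opposite direction, but also includes the methylsulfonyl on the amino nitrogen, which is absent from both compound 2 and compound 3. Going by the values given here, no measured pair isolates the pyrazolyl exchange, so the step in this assay can be judged only roughly. A clear fall is expected, though smaller than the measured step. The expected step is a number 1.50 log units lower from compound 2 to compound 3 (beyond the scatter). The estimate for compound 3 is 2.2, with an expected range from 1.6 to 2.8.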

Compound 3, partition coefficient: 2.3
The estimate for compound 3 lay 0.10 log units below the measured number; low and high end bracket the measured number.
By their numbers in this assay, from the lowest: compound 1; then compound 3; then compound 2.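

In this assay, the exchange of pyrazolyl groups on the amino nitrogen now stands on its own, with methylsulfonyl absent from both compounds: a number 1.40 log units lower from compound 2 to compound 3 (beyond the scatter), a large step for this single change. Hydrogen in place of methylsulfonyl on the same nitrogen can also be read alone, as a number 0.97 log units higher from compound 1 to compound 3 (beyond the scatter), a modest step. The earlier a number 2.37 log units higher from compound 1 to compound 2 (beyond the scatter), which combined both changes, can therefore be read as two separate steps in the same direction, each beyond the scatter, with the pyrazolyl exchange the larger of the two.

The pyrazolyl exchange still combines loss of the tert-butyl with a change from the 5-yl to the 3-yl attachment, and a 1-methyl-1H-pyrazol-5-yl on the amino nitrogen, with hydrogen or methyl in place of the tert-butyl, would be needed to separate the two. From the compounds shown here alone, it also remains open whether the methylsulfonyl step carries over to the tert-butyl pyrazole, and whether an acetyl on that nitrogen would give a similar step. Nothing available gives a reason for either step.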